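Cytotoxicity notes on a benzyl-group swap

A few compounds are considered here, and "the series" means these few. Any claim that something is new, unique, unknown or untested is made for them only; others in the source may bear on it.

Measured so far in an ADME assay on MT4 cells (Homo sapiens) for cytotoxicity, read by MTT assay, with a stated time of 5 days; on this read-out higher numbers stand for lower toxicity in this test and lower numbers for higher toxicity in this test:
compound 1 `Cc1ccc(Cn2cc(CNC(=O)c3cnc(Nc4ccc(C#N)cc4)cc3Oc3c(C)cc(C)cc3C)nn2)cc1` gives 165000 nM
compound 2 `Cc1cc(C)c(Oc2cc(Nc3ccc(C#N)cc3)ncc2C(=O)NCc2cn(Cc3ccccc3C#N)nn2)c(C)c1` gives > 219000 nM
compound 3 `Cc1cc(C)c(Oc2cc(Nc3ccc(C#N)cc3)ncc2C(=O)NCc2cn(CCCO)nn2)c(C)c1` gives 25200 nM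

The entry for compound 2 is only a limit of this assay, not a number (the limit of > 219000 nM in this assay, at which 1 of the 3 values shown sits). The step of an at least 1.3-fold higher number from compound 1 to compound 2 (0.12 log units; that floor lies within the scatter) shows that exchanging one aryl group for another left the read-out within the scatter, whereas an at least 8.6-fold lower number from compound 2 to compound 3 (0.93 log units; beyond the scatter) and a 6.5-fold lower number from compound 1 to compound 3 (0.82 log units; beyond the scatter) show that replacing the aryl group with 2-hydroxyethyl gave modestly lower numbers.

Compound 4 `Cc1cc(C)c(Oc2cc(Nc3ccc(C#N)cc3)ncc2C(=O)NCc2cn(Cc3cccc([N+](=O)[O-])c3)nn2)c(C)c1` differs from compound 2 by 3-nitrophenyl in place of 2-cyanophenyl on a saturated chain carbon bound to an aromatic nitrogen. Because an at least 1.3-fold higher number from compound 1 to compound 2 (0.12 log units; that floor lies within the scatter) shows that exchanging one aryl group for another left the read-out within the scatter and compound 4 likewise keeps an aryl group, the expected step in this assay is an at least 1.2-fold lower number from compound 2 to compound 4 (0.10 log units; that floor lies within the scatter), i.e. none beyond the scatter. Compound 4 is therefore estimated at 170000 nM, with a range from 70000 nM to 300000 nM.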

Compound 4, half-maximal cytotoxic concentration: >= 156000 nM
Compound 4: only a limit was reported; the forecaster's own chance of this, stated with the estimate: 40%; the middle value lies beyond the limit too.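

Compound 4 holds only a limit, not a number, in this read-out: the limit of >= 156000 nM in this assay, at which 1 of the 4 values shown sits. The steps from compound 1 and from compound 2 to compound 4 therefore cannot be read. On the saturated chain carbon bound to an aromatic nitrogen, a third aryl group, 3-nitrophenyl, also separates from 2-hydroxyethyl, with an at least 6.1-fold higher number from compound 3 to compound 4 (0.79 log units; beyond the scatter), and no compound shown goes against this.

As far as these compounds go, the order among the aryl groups stays open. So does the place of 2-aminoethyl or a carboxylic acid on a longer chain, relative to 2-hydroxyethyl and the aryl groups.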